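Demethylation Step Carried Over to a Second Core

A few compounds are considered here, and "the series" means these few. Any claim that something is new, unique, unknown or untested is made for them only; others in the source may bear on it.

Compound 1 `COc1cc(OC)c(C(=O)/C=C/c2ccccc2SC)c(OC)c1` and compound 2 `COc1cccc(/C=C/C(=O)c2c(OC)cc(OC)cc2OC)c1` share a core and differ only in the aryl group on the chain: 3-methoxyphenyl in place of 2-(methylsulfanyl)phenyl on a double-bonded chain carbon bound to a double-bonded chain carbon. In a functional assay on PC-3 cells (Homo sapiens), read by fluorescence and BrdU incorporation, with a stated time of 48 h, tested at 25 uM (a lower number here means a stronger effect, a higher number a weaker effect of the compound at the concentration tested), compound 1 gives 0% and compound 2 gives 0.9%, the step being a number 0.9 percentage points higher from compound 1 to compound 2 (within the scatter), so the two aryl groups are not told apart by this read-out. Compound 3 `COc1cc(O)c(C(=O)/C=C/c2ccccc2SC)c(OC)c1` carries one change relative to compound 1: hydrogen in place of methyl on an oxygen on an aromatic ring. In this assay compound 3 gives 31%, a step of a number 31 percentage points higher from compound 1 to compound 3 (beyond the scatter), the only move beyond the scatter among the three measured compounds. Compound 4 `COc1cccc(/C=C/C(=O)c2c(O)cc(OC)cc2OC)c1` stands to compound 2 as compound 3 stands to compound 1: hydrogen in place of methyl on an oxygen on an aromatic ring, and the surroundings of the place are worded identically in both cases, so this is the same change applied to the other core. Among the measured compounds shown here, compound 4 is expected to show a step of a number 26.1 percentage points higher from compound 2 to compound 4 (beyond the scatter) of the same sign and of roughly the same size as a number 31 percentage points higher from compound 1 to compound 3 (beyond the scatter), resting on compound 3 and on the near-equal values of compound 1 and compound 2, with some allowance for a smaller step since only one earlier instance exists. Compound 4 is accordingly estimated at 27%, with a likely span from 8% to 45%.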

Compound 4, a percentage reported as activity, at one concentration (the size of the read-out at that concentration, not a potency): 9.4%
Estimate against measurement, compound 4: 17.6 percentage points above; measured number inside the range.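

Methoxy to hydroxy on the core of compound 2 gives, in this assay, a number 8.5 percentage points higher from compound 2 to compound 4 (within the scatter), and the two cores do not share one step size for this change: the same change on two cores in this assay, a number 31 percentage points higher (beyond the scatter) from compound 1 to compound 3 and a number 8.5 percentage points higher (within the scatter) from compound 2 to compound 4, 22.5 percentage points apart, beyond the scatter of two such steps. The large step on the core of compound 1 therefore cannot be carried to the core of compound 2 as a fixed increment, and a step beyond the scatter is seen on one core only. With one pair per core and a read-out at a single concentration, these data give neither a cause for the gap nor any measure of potency, and they do not show how the change would behave on a further core.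

Left open is whether the gap between the two steps persists with aryl groups on the chain other than 2-(methylsulfanyl)phenyl and 3-methoxyphenyl. Also open, on these data alone, is how an amine or a carboxylic acid in place of the hydroxy, or a longer chain such as ethoxy on that oxygen, would read out on either core.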